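The source may report more compounds than this note shows. Statements on the series, on what has been measured and on what is new or still open speak of the compounds shown alone.

Compound 1 `Clc1ccc(NCc2cn(-c3ccccc3)nc2-c2ccc(Cl)cc2)cc1` gives 90000 nM in an ADME assay on Vero 76 cells (Chlorocebus sabaeus) for cytotoxicity, read by MTT assay, with a stated time of 96 h; on this read-out higher numbers stand for lower toxicity in this test and lower numbers for higher toxicity in this test.
Compound 2 `Cc1ccc(NCc2cn(-c3ccccc3)nc2-c2ccc(Cl)cc2)cc1` gives > 100000 nM in this assay, which is a limit of the assay, not a number.
Compound 3 `FC(F)(F)c1ccc(-c2nn(-c3ccccc3)cc2CNc2ccc(Br)cc2)cc1` gives 17000 nM in this assay.

Compound 2 thus stands at the upper limit, (the limit of > 100000 nM in this assay, at which 1 of the 3 values shown sits), so only a floor is known for it; compound 1 and compound 3 both return numbers below that floor. Going by the values given here, the one measured step that differs in a single place, an at least 1.1-fold higher number from compound 1 to compound 2 (0.04 log units; that floor lies within the scatter), changed the group on the aniline ring and moved the value to the limit, though its floor lies within the scatter.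

Compound 4 `Cc1ccc(NCc2cn(-c3ccccc3)nc2-c2ccccc2)cc1` differs from compound 2 at the other aryl ring: hydrogen in place of chloro on an aromatic carbon. Among the compounds with values here, no measured step touches this ring, so nothing here gauges the size of that change; the expectation rests on compound 2 sitting at the limit and on the small size of the one measured step. The step is expected to be a number no higher from compound 2 to compound 4 (the limit leaves the size open), none beyond the scatter. Compound 4 is therefore estimated at 100000 nM, within 40000 nM to 300000 nM, with a fair chance that only a limit is again reported.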

Compound 4, half-maximal cytotoxic concentration: > 100000 nM
Compound 4 gave a limit, no number (the forecaster's own chance of this, stated with the estimate: 55%); the middle value lies on the limit itself.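

Compound 2 and compound 4 each return only a limit, so no step can be read between them: the limit of > 100000 nM in this assay, at which 2 of the 4 values shown sit. The compounds shown leave open how far either lies past that limit, and so what hydrogen in place of chloro does to the value here.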